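Shortening the Pentyl Chain of Compound 1

The source may hold more compounds than are shown below. What is called first, only, known or untested is meant among the compounds shown, and "the series" means these compounds.

Going by the values given here, compound 1 `CCCCCOCNc1n[n+]([O-])c2ccccc2[n+]1[O-]` shows the highest number of the three measured so far: in a functional assay on K562 cells (Homo sapiens) for cytotoxicity, read by MTT assay, with a stated time of 72 h (a higher number here means a weaker inhibitor, a lower number a stronger inhibitor), compound 1 gives 14500 nM. Compound 3 `CC(OCNc1n[n+]([O-])c2ccccc2[n+]1[O-])c1ccccc1` gives 8720 nM, which lies within the scatter of compound 1. Compound 2 `CCCCCOCNc1n[n+]([O-])c2cc(OC)ccc2[n+]1[O-]` gives 7110 nM, and the step of a 2.0-fold lower number from compound 1 to compound 2 (0.31 log units; beyond the scatter) is the only one that reaches beyond the scatter. Compound 4 `CCCCOCNc1n[n+]([O-])c2ccccc2[n+]1[O-]` differs from compound 1 by hydrogen in place of methyl on a saturated chain carbon, four bonds along the chain from an oxygen on a saturated carbon. Among the compounds with values here, no measured step touches the chain; the one recorded step concerns a methoxy in place of hydrogen on an aromatic carbon and offers no guidance here. The expected step of no change at the digits printed from compound 1 to compound 4 (within the scatter) is therefore none beyond the scatter. Compound 4 is estimated at 14500 nM, with a range from 6500 nM to 32000 nM.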

Compound 4, half-maximal inhibitory concentration: 17600 nM
Estimate against measurement, compound 4: 1.2-fold (0.08 log units) below, within the range that was stated.
By their numbers in this assay, from the lowest: compounds 2, 3, 1 and 4 (each within the scatter of the next, the first and the last beyond it).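

Hydrogen in place of methyl on a saturated chain carbon, four bonds along the chain from an oxygen on a saturated carbon, gives a 1.2-fold higher number from compound 1 to compound 4 (0.08 log units; within the scatter) in this assay. Going by these compounds alone, this is the first measured step on the chain itself, and it shows that losing this one carbon leaves the number within the scatter. No evidence is available on what lies behind this result. Going by these compounds, whether further cuts, such as butyl to propyl, would also stay within the scatter remains open, as does the effect of a longer chain or an amine at this position.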